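The compounds below may be only part of what the source reports. "The series", "measured", "known", "first", "only" and "open" are said of these compounds alone.

Notes on the series. Compound 1 `OC[C@]1(c2ccc(F)cc2)NC[C@H](O)[C@H]1O` and compound 2 `C[C@]1(CO)NC[C@@H](O)[C@@H]1O` share the core and have both been measured in an assay on isolated protein for inhibition of tissue alpha-L-fucosidase (Bos taurus), tested at 1000 uM; a lower number here means less inhibition, a higher number more inhibition at the concentration tested (going by the name of the read-out). Compound 1 gives 0% in this assay, and compound 2 gives 10.9%. Of the two numbers, compound 1 stands lowest, with compound 2 the nearest, higher by an amount beyond the usual scatter. Among the measured compounds shown here, no pair of measured compounds differing in a single place is available, so the move to compound 3 `Cc1ccc([C@@]2(CO)NC[C@H](O)[C@H]2O)cc1` rests on compound 1 alone. The change is methyl in place of fluoro on an aromatic carbon. Fluoro leaves and methyl enters on an aromatic carbon of the six-membered aromatic ring of carbon only. Because compound 1 gives 0% in this assay, the step of a number 3 percentage points higher from compound 1 to compound 3 (within the scatter) is expected to be none beyond the scatter, upward if at all. Compound 3 is estimated at 3%, within 0% to 15%.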

Compound 3, a percentage reported as inhibition, at one concentration (the size of the read-out at that concentration, not a potency): 3.3%
The estimate for compound 3 lay 0.3 percentage points below the measured number; the measured number falls inside the stated range.
By their numbers in this assay, from the lowest: compounds 1, 3 and 2 (each within the scatter of the next, the first and the last beyond it).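

In this assay, methyl in place of fluoro on an aromatic carbon, para to a group of 9 heavy atoms, gives a number 3.3 percentage points higher from compound 1 to compound 3 (within the scatter). Among the compounds shown here, this is the first comparison between compounds that differ in one place, and at this position the two groups cannot be told apart at the single concentration tested. Nothing available on these compounds bears on the reason for this result.

Still open, on these data alone, is whether any other group at this position, such as an amine, a carboxylic acid or a longer chain, would move the read-out beyond the scatter. As far as these compounds go, a percentage at one concentration also gives no potency for compound 1 or compound 3, so any difference between them at other concentrations remains unknown.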